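The source may report more compounds than this note shows. Statements on the series, on what has been measured and on what is new or still open speak of the compounds shown alone.

In a functional assay on L1210 cells (Mus musculus) for inhibition (a lower number here means a stronger inhibitor, a higher number a weaker inhibitor), compound 1 `O=C1/C(=C/c2ccc(Br)cc2)Cc2ccccc21` gives 64800 nM and compound 3 `O=C1CCCCC/C1=C\c1ccc(Br)cc1` gives 68400 nM, two numbers within the scatter of each other. Compound 2 `COc1ccc(/C=C2\CCCc3ccccc3C2=O)cc1` gives 340 nM, far lower and beyond the scatter. Compound 3 therefore stands at the top of this small set, level with compound 1. Compound 4 `CN(C)c1ccc(/C=C2\CCCCCC2=O)cc1` keeps the core of compound 3 and changes one group: dimethylamino in place of bromo on an aromatic carbon. Going by the values given here, no measured pair isolates this swap. Compound 2, at 340 nM, carries no bromo, but its core also differs, so it offers only a weak hint of a lower number. A moderate drop is expected, a 3.4-fold lower number from compound 3 to compound 4 (0.53 log units; beyond the scatter). For compound 4 the estimated value is 20000 nM, with an expected range from 4000 nM to 80000 nM.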

Compound 4, half-maximal inhibitory concentration: 79100 nM
The estimate for compound 4 lay 4.0-fold (0.60 log units) below the measured number; the measured number falls inside the stated range.
By their numbers in this assay, from the lowest: compound 2; then compounds 1, 3 and 4 (each within the scatter of the next).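

Going by these compounds alone, with the core of compound 3 held fixed, dimethylamino in place of bromo on the aromatic carbon gives a 1.2-fold higher number from compound 3 to compound 4 (0.06 log units; within the scatter) in this assay, the first measured pair to isolate this swap. On this core, then, removing the bromo and adding dimethylamino does not shift the number beyond the scatter. Nothing available explains why these two groups read alike.

As far as these compounds go, whether a nitrile or a carboxylic acid at this place would read differently stays open. So does whether the same swap would behave alike on the other cores shown.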